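The source may report more compounds than this note shows. Statements on the series, on what has been measured and on what is new or still open speak of the compounds shown alone.

Measured compounds:
compound 1, `O=C(C1CCC1)N1CCC[C@H](c2nc(-c3cccs3)no2)C1`, giving 9300 nM in an in vitro functional assay on HEK293-A cells for negative allosteric modulation of metabotropic glutamate receptor 5 (Homo sapiens), read by fluorescence and calcium flux, with a stated time of 140 s; on this read-out higher numbers stand for weaker inhibition and lower numbers for stronger inhibition
compound 2, `O=C(C1CCC1)N1CCCC[C@@H]1c1nc(-c2cccc(Cl)c2)no1`, giving 10000 nM in this assay

On these two numbers compound 2 stands alongside compound 1: the gap between them lies within the usual scatter of repeated measurements, so nothing can be said about which of the two is the weaker inhibitor. Both sit in a range where inhibition is modest.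

Compound 3, `O=C(C1CCC1)N1CCCC[C@H]1c1nc(-c2cccc(Cl)c2)no1`, is the unmeasured partner of compound 2. The change from compound 2 to compound 3 is the two compounds have the same atoms and bonds and differ only in configuration as drawn: 1 of 1 stereo elements differ; a stereocentre at a saturated ring carbon is drawn R in compound 2 and S in compound 3; the two compounds have the same atoms and bonds and differ only in configuration as drawn, at a stereocentre on a saturated ring carbon. For the measured compounds named here, no measured pair here shows what a change of configuration does, so the direction of the step is not anchored by the data. Pairs differing only at one stereocentre can be indistinguishable or can differ strongly, and the wide range of the estimate reflects that. The step is expected as a 2.5-fold lower number from compound 2 to compound 3 (0.40 log units; beyond the scatter), with a larger chance of stronger than of weaker inhibition, since compound 2 already sits near the weak end. Compound 3 is therefore estimated at 4000 nM, with a range from 600 nM to 25000 nM.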

Compound 3, half-maximal inhibitory concentration: 900 nM
Beside the measured number, compound 3's estimate is 4.4-fold (0.65 log units) above it, within the range that was stated.
By their numbers in this assay, from the lowest: compound 3; then compounds 1 and 2 (each within the scatter of the next).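

In this assay the stereocentre at the saturated ring carbon proves to be a position that matters, since redrawing it from R to S gives an 11-fold lower number from compound 2 to compound 3 (1.05 log units; beyond the scatter). For the compounds shown here, the earlier numbers could not show this: they lay within the scatter of each other, belonged to compounds differing in more than one place, and included no pair that isolated configuration. The step can be assigned to the stereocentre alone, with no contribution from any change of substituent, because the pair offers no other difference: the fact that compounds 2 and 3 differ only in the configuration as drawn

Going by these compounds alone, the single pair shows that, with the chlorine and the cyclobutane carbonyl held fixed, the S drawing gives the stronger inhibition, but it does not show whether that preference carries over to other members, including compound 1, whose own stereocentre appears in one configuration only. It also leaves open whether compound 3 would keep its advantage over compound 2 if a methoxy group or an amine stood in place of the chlorine, and so whether the effect of configuration depends on that substituent.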